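A few compounds are considered here, and "the series" means these few. Any claim that something is new, unique, unknown or untested is made for them only; others in the source may bear on it.

In a functional assay on MCF7 cells (Homo sapiens) for antiproliferative activity, read by MTT assay, with stated times of 24 h and 72 h (a lower number here means a stronger inhibitor, a higher number a weaker inhibitor), compound 1 `COc1ccc([C@@H]2[C@H](Oc3ccccc3)C(=O)N2c2cc(OC)c(OC)c(OC)c2)cc1OC`, with 3,4-dimethoxyphenyl on a saturated ring carbon, gives 26000 nM. With naphthalen-1-yl on that carbon, compound 2 `COc1cc(N2C(=O)[C@@H](Oc3ccccc3)[C@H]2c2cccc3ccccc23)cc(OC)c1OC` gives 53000 nM. With 4-nitrophenyl there, compound 3 `COc1cc(N2C(=O)[C@@H](Oc3ccccc3)[C@H]2c2ccc([N+](=O)[O-])cc2)cc(OC)c1OC` gives 63000 nM. Compound 3 has the highest of the three numbers, but it cannot be separated from compound 2, as a 1.2-fold higher number from compound 2 to compound 3 (0.08 log units; within the scatter) shows. It differs more clearly from compound 1, with a 2.4-fold higher number from compound 1 to compound 3 (0.38 log units; beyond the scatter).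

Compound 4 `COc1cc(N2C(=O)[C@@H](Oc3ccccc3)[C@H]2c2ccc(O)c(O)c2)cc(OC)c1OC` has 3,4-dihydroxyphenyl in place of 4-nitrophenyl on a saturated ring carbon.

Within the data shown here, three measured steps bear on this change, all at the same ring carbon. Besides the two above, there is a 2.0-fold higher number from compound 1 to compound 2 (0.31 log units; beyond the scatter). These steps are modest or within the scatter, so swapping this group has not moved this assay much so far. Among the measured compounds shown here, no measured compound carries 3,4-dihydroxyphenyl. The closest group by name is the 3,4-dimethoxyphenyl of compound 1, at 26000 nM, which suggests a shift toward a lower number. A modest shift in that direction is expected, and the estimated step is a 1.8-fold lower number from compound 3 to compound 4 (0.24 log units; within the scatter). The expected value for compound 4 is 36000 nM, with an estimated range of 13000 nM to 90000 nM.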

Compound 4, half-maximal inhibitory concentration: 4500 nM
Compound 4: middle estimate off by 8.0-fold (0.90 log units), on the high side, and the stated range ends above it.
By their numbers in this assay, from the lowest: compound 4; then compound 1; then compounds 2 and 3 (each within the scatter of the next).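

In this assay this position turns out to carry far more range than the earlier swaps suggested: the step of a 14-fold lower number from compound 3 to compound 4 (1.15 log units; beyond the scatter) and the step of a 12-fold lower number from compound 2 to compound 4 (1.07 log units; beyond the scatter) are both large, where those swaps stayed modest or within the scatter. The closest comparison also separates two groups that looked alike by name, as the step of a 5.8-fold lower number from compound 1 to compound 4 (0.76 log units; beyond the scatter) shows that 3,4-dihydroxyphenyl and 3,4-dimethoxyphenyl are not interchangeable on this saturated ring carbon. Of the four groups compared here, only 3,4-dihydroxyphenyl carries hydrogen-bond donors, but this is an observation from four compounds and not an explanation of the gain.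

No measurement at hand accounts for the gain.

The compounds shown leave open whether both hydroxyl groups are needed, which 3-hydroxyphenyl and 4-hydroxyphenyl on the same carbon would test against compound 4. They also leave open whether other groups on this ring position, such as 3,4-diaminophenyl or 4-carboxyphenyl, would give numbers near that of compound 4 or near those of the weaker members of the series.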